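Removing the Fluoro Group From Compound 3: Expected Cytotoxicity

This account rests on a few compounds, and the source may have more. Where it says the series, first, only, none or still open, it means among the compounds named here.

Of the compounds shown here, three have been measured in an ADME assay on Vero cells (Chlorocebus sabaeus) for cytotoxicity, read by WST assay, tested at 100 ug/mL; on this read-out lower numbers stand for a stronger effect and higher numbers for a weaker effect at the one concentration tested. Compound 1 `COC(=O)[C@@H]1COC(/C=C/c2ccc(F)cc2)=N1` gives 18.6%, and compound 2 `COC(=O)[C@@H]1COC(/C=C/c2ccc(C)cc2)=N1` gives 17%. These two differ only by a methyl in place of fluoro on an aromatic carbon, and that step, a number 1.6 percentage points lower from compound 1 to compound 2 (within the scatter), lies within the scatter. Going by the values given here, compound 3 `COC(=O)c1coc(/C=C/c2ccc(F)cc2)n1` gives 99%, the highest of the three numbers, far above both compound 1 and compound 2; its core differs from theirs, and no single-change step connects it to either.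

Compound 4 `COC(=O)c1coc(/C=C/c2ccccc2)n1` is not yet measured. It differs from compound 3 by hydrogen in place of fluoro on an aromatic carbon. Among the compounds with values here, the only measured step that resembles this change is the exchange of one group for another on the same kind of aromatic carbon between compound 1 and compound 2, which was within the scatter. On that basis the change from compound 3 to compound 4 is expected to produce no step beyond the scatter in this assay, that is a number 4 percentage points lower from compound 3 to compound 4 (within the scatter). Compound 4 is therefore estimated to give 95%, with a likely range from 80% to 100%, as the read-out cannot rise much further.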

Compound 4, a percentage reported as activity, at one concentration (the size of the read-out at that concentration, not a potency): 102%
Beside the measured number, compound 4's estimate is 7 percentage points below it; the measured number lies above the stated range.
By their numbers in this assay, from the lowest: compounds 2 and 1 (each within the scatter of the next); then compounds 3 and 4 (each within the scatter of the next).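

On the core of compound 3, the fluoro group on this aromatic carbon, para to a large group, can give way to plain hydrogen with little effect on the read-out in this assay, the step being a number 3 percentage points higher from compound 3 to compound 4 (within the scatter). Going by these compounds alone, until now the only step at this place was an exchange of one group for another on the core of compound 1, a number 1.6 percentage points lower from compound 1 to compound 2 (within the scatter), so this result adds a second core and a different change, the loss of the group altogether, and both steps stay within the scatter. Nothing measured here explains why the read-out stays so close across this change.

The compounds shown leave open whether an amine or a carboxylic acid on this aromatic carbon would also keep the number where it is, on either core. On these data alone, it also remains open whether hydrogen in place of fluoro on the core of compound 1, where the effect at the tested concentration is much stronger, would give a step as small as the one seen on the core of compound 3.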